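Working notes: carbamoyl in place of amino, compound 4

The compounds below may be only part of what the source reports. "The series", "measured", "known", "first", "only" and "open" are said of these compounds alone.

Measured in a functional assay on HBC5 cells (Homo sapiens) for inhibition, read by sulforhodamine B assay, with a stated time of 48 h; on this read-out higher numbers stand for weaker inhibition of growth and lower numbers for stronger inhibition of growth:
- compound 1 `CCCCCCCCCCCC[C@@H](O)[C@H]1CC[C@H]([C@H](O)CCCCCCCCCCNC(=O)c2ccnn2C)O1`: 17000 nM
- compound 2 `CCCCCCCCCCCC[C@@H](O)[C@H]1CC[C@H]([C@H](O)CCCCCCCCCCN(C)C(=O)c2ccnn2C)O1`: 3090 nM
- compound 3 `CCCCCCCCCCCC[C@@H](O)[C@H]1CC[C@H]([C@H](O)CCCCCCCCCCNCc2ccnn2C)O1`: 2090 nM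

Compound 3 gives 2090 nM, and a 1.5-fold lower number from compound 2 to compound 3 (0.17 log units; within the scatter) shows no separation from its nearest neighbour. The next structure is compound 4 `CCCCCCCCCCCC[C@@H](O)[C@H]1CC[C@H]([C@H](O)CCCCCCCCCCC(=O)Nc2ccnn2C)O1`, and the change is (1-methyl-1H-pyrazol-5-yl)carbamoyl in place of ((1-methyl-1H-pyrazol-5-yl)methyl)amino on a saturated chain carbon, ten or more bonds along the chain from an oxygen on a saturated carbon and a saturated ring carbon. Going by the values given here, the steps that bear on it are a 5.5-fold lower number from compound 1 to compound 2 (0.74 log units; beyond the scatter) and an 8.1-fold lower number from compound 1 to compound 3 (0.91 log units; beyond the scatter), both modest and both leading away from the only measured compound with a hydrogen on an amide-type nitrogen. Among the compounds with values here, compound 4 also holds such a hydrogen, within a carbamoyl group that no measured compound carries, so this comparison is indirect. Compound 1, the nearest guide, stands at 17000 nM, and only part of that gap is expected to return. In this assay the expected change is a modest one toward a higher number, estimated as a 3.3-fold higher number from compound 3 to compound 4 (0.52 log units; beyond the scatter). For compound 4 the estimate is 7000 nM, with an expected range from 2500 nM to 20000 nM.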

Compound 4, concentration for 50% growth inhibition: 100000 nM
Compound 4: the middle estimate sits 14-fold (1.15 log units) below what was measured, and the stated range ends below it.
By their numbers in this assay, from the lowest: compounds 3 and 2 (each within the scatter of the next); then compound 1; then compound 4.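

In this assay, (1-methyl-1H-pyrazol-5-yl)carbamoyl on this saturated chain carbon gives a 48-fold higher number from compound 3 to compound 4 (1.68 log units; beyond the scatter) and a 32-fold higher number from compound 2 to compound 4 (1.51 log units; beyond the scatter), both large and larger than any step seen earlier in the series. The position therefore responds strongly to this change, and the reversed amide is not equivalent to the amide of compound 1, as a 5.9-fold higher number from compound 1 to compound 4 (0.77 log units; beyond the scatter) shows; among the four compounds, the two holding the amide hydrogen, compound 1 and compound 4, give the two highest numbers. No measurement here accounts for this result.

From the compounds shown here alone, whether methyl on the amide nitrogen of compound 4 would bring a step like a 5.5-fold lower number from compound 1 to compound 2 (0.74 log units; beyond the scatter) remains open. Also open, going by these compounds, is how a carboxylic acid or a simple tertiary amine at this chain end would compare with compound 3.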